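The compounds below may be only part of what the source reports. "The series", "measured", "known", "first", "only" and "open" are said of these compounds alone.

Measured compounds:
Compound 1, `CN(Cc1cn(C2CCCCC2OC(=O)c2ccccc2)nn1)CC1CCCCC1`: 32%
Compound 2, `CN(Cc1cn(C2CCCCC2OC(=O)COc2ccccc2)nn1)CC1CCCCC1`: 37%
Compound 3, `CCCCNC(=O)OCC(O)Cn1cc(CN2CCN(c3ccccc3)CC2)nn1`: 11%

In an assay on nucleic acid for inhibition of Nucleic Acid, read by fluorescence, tested at 100 uM (on this read-out lower numbers stand for less inhibition and higher numbers for more inhibition at the one concentration tested (going by the name of the read-out)), compound 1 gives 32%, the second highest of the three numbers. Among the compounds with values here, its nearest neighbour is compound 2, and the single measured step, a number 5 percentage points higher from compound 1 to compound 2 (within the scatter), lies within the scatter, so the two cannot be put in order. The furthest is compound 3, whose value of 11% sits beyond the scatter below that of compound 1; compound 3 differs from compound 1 in several places at once, so its number shows only the gap between the two and no single change.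

Compound 4, `CC(C)CCN(C)Cc1cn(C2CCCCC2OC(=O)c2ccccc2)nn1`, is still to be measured in this assay. It differs from compound 1 in one place: isobutyl in place of cyclohexyl on a saturated chain carbon bound to an amine nitrogen. Within the data shown here, the one step that has been measured alters the ester side of the molecule, not the chain on the amine nitrogen, and it was within the scatter; no measured step bears on the present change. An expectation must therefore rest on compound 1 alone, and no step beyond the scatter is expected: a number 2 percentage points lower from compound 1 to compound 4 (within the scatter). For compound 4 the estimate in this assay is 30%, expected to lie between 15% and 45%.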

Compound 4, a percentage reported as inhibition, at one concentration (the size of the read-out at that concentration, not a potency): 26%
Compound 4: the middle estimate sits 4 percentage points above what was measured; the range from low to high includes it.
By their numbers in this assay, from the lowest: compound 3; then compounds 4, 1 and 2 (each within the scatter of the next, the first and the last beyond it).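

In this assay, within the data shown here, the earlier compounds offered no pair that varied the group on the amine nitrogen, and the present pair supplies the first such reading: isobutyl in place of cyclohexyl on a saturated chain carbon bound to an amine nitrogen gives a number 6 percentage points lower from compound 1 to compound 4 (within the scatter) in this series. With the phenyl ester held constant, then, the one six-membered non-aromatic ring of carbon only can be exchanged for an open chain of 4 heavy atoms with no step beyond the scatter, so in this single pair the read-out does not depend on that ring being present. Nothing available accounts for this result or says what the two groups do in the assay.

The compounds shown leave open whether the same exchange would hold on the phenoxymethyl ester of compound 2, since only the phenyl ester carries both groups. They also leave open how the read-out would respond to a phenyl ring, a much shorter chain such as ethyl, or a chain ending in a hydroxyl group or a carboxylic acid in this same place, as neither cyclohexyl nor isobutyl says anything about such groups.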